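Series notes: (4-methoxyphenyl)amino in place of 4-chlorophenyl

The compounds below may be only part of what the source reports. "The series", "measured", "known", "first", "only" and "open" are said of these compounds alone.

Compound 1 `C[C@@H](c1nnc(-c2ccc(Cl)cc2)o1)[C@H]1CC[C@@H](c2ccnc3ccc(F)cc32)CC1` serves as the reference point. In an ADME assay on microsomes from liver (Homo sapiens) for metabolic stability, with a stated time of 10 min, tested at 0.5 uM (a higher number here means that more of the compound is left, a lower number that less of the compound is left), compound 1 gives 68%, the lowest of the three numbers recorded. Compound 2 `CCC(Nc1nnc(-c2ccc(OC)cc2)o1)[C@H]1CC[C@H](Oc2ccnc3ccccc23)CC1` gives 83% in this assay, a separation from compound 1 beyond the scatter. Compound 3 `C[C@@H](c1ncc(-c2ccc(Cl)cc2)o1)[C@H]1CC[C@@H](c2ccnc3ccc(F)cc32)CC1` gives 97% in this assay, the furthest from compound 1 and also beyond the scatter. Compound 4 `COc1ccc(Nc2nnc([C@H](C)[C@H]3CC[C@@H](c4ccnc5ccc(F)cc54)CC3)o2)cc1` has not been measured. The change from compound 1 to compound 4 is (4-methoxyphenyl)amino in place of 4-chlorophenyl on an aromatic carbon. Among the measured compounds shown here, no measured pair shows this exchange, so the size of the step is open; a moderate rise is expected rather than a fall, though a step within the scatter cannot be excluded. In this assay compound 4 is estimated at 75%, with a range of 55% to 92%. The expected step of a number 7 percentage points higher from compound 1 to compound 4 (within the scatter) is thus a small upward one.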

Compound 4, percent of the compound remaining: 18%
Compound 4: the middle estimate sits 57 percentage points above what was measured; the measured number lies below the stated range.
By their numbers in this assay, from the lowest: compound 4; then compound 1; then compound 2; then compound 3.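

In this assay, among the compounds shown here, the exchange of 4-chlorophenyl for (4-methoxyphenyl)amino on this aromatic carbon of the five-membered ring gives a number 50 percentage points lower from compound 1 to compound 4 (beyond the scatter), the first direct reading at this position. The number therefore depends strongly on the group held there, with the rest of compound 1 unchanged. Nothing at hand accounts for the size of this step.

Still open, as far as these compounds go, is whether the step follows the amine nitrogen or the methoxy group. A directly attached 4-methoxyphenyl or a (4-chlorophenyl)amino group at this carbon would separate the two.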